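Compound 2 to Compound 4: Trifluoromethyl to Hydrogen

The source may report more compounds than this note shows. Statements on the series, on what has been measured and on what is new or still open speak of the compounds shown alone.

Three compounds on a shared core were tested in a functional assay on DU-145 cells (Homo sapiens) for cytotoxicity, read by sulforhodamine B assay, with a stated time of 48 h; a higher number here means a weaker inhibitor of growth, a lower number a stronger inhibitor of growth. Compound 1 `N#Cc1ccc(Nc2nc(Oc3ccnc4ccccc34)nc(N3CCN(C(c4ccccc4)c4ccc(Cl)cc4)CC3)n2)cc1C(F)(F)F` reached only the limit of the assay, > 100000 nM. Compound 3 `N#Cc1ccc(Nc2nc(Oc3ccnc4ccccc34)nc(N3CCC(Cc4ccccc4)CC3)n2)cc1C(F)(F)F` likewise gave only a limit, > 100000 nM. Within the data shown here, compound 2 `N#Cc1ccc(Nc2nc(Oc3ccnc4ccccc34)nc(N3CCN(c4cccc(C(F)(F)F)c4)CC3)n2)cc1C(F)(F)F` is the one with a number, 38700 nM, while the other two sit at the limit of > 100000 nM in this assay, at which 2 of the 3 values shown sit. Compound 4 `N#Cc1ccc(Nc2nc(Oc3ccnc4ccccc34)nc(N3CCN(c4ccccc4)CC3)n2)cc1C(F)(F)F` differs from compound 2 in one place: hydrogen in place of trifluoromethyl on an aromatic carbon. Among the measured compounds shown here, no measured step matches this change, so the expectation rests on compound 2 alone. The step from compound 2 to compound 4 is expected to be a 1.6-fold higher number from compound 2 to compound 4 (0.19 log units; within the scatter), a mild loss that may not exceed the scatter. Compound 4 is therefore estimated at 60000 nM, between 25000 nM and 150000 nM, in this assay.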

Compound 4, concentration for 50% growth inhibition: > 100000 nM
Compound 4: no number, only a limit; the forecaster's own chance of this, stated with the estimate: 40%; middle value at least 1.6-fold (0.22 log units) away from the limit.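

The change from 3-(trifluoromethyl)phenyl to phenyl gives an at least 2.5-fold higher number from compound 2 to compound 4 (0.41 log units; beyond the scatter), so this substituent on an aromatic carbon matters to the read-out in this assay. Compound 4 gives only a limit, > 100000 nM, so the full size of the step cannot be read. Of the four compounds, only compound 2 retains a number, and the others share one limit: the limit of > 100000 nM in this assay, at which 3 of the 4 values shown sit.

Going by these compounds, whether a chlorine, a methoxy group or an amine at this place would retain the number of compound 2 remains open. So does the effect of a second trifluoromethyl on the same ring.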